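Oxime ether series: a ring-fused replacement for the benzyl group

The source may hold more compounds than are shown below. What is called first, only, known or untested is meant among the compounds shown, and "the series" means these compounds.

Three compounds of the shared core carry an oxime ether on the same position and have been measured in an assay on HepG2 cells for agonist activity at nuclear receptor subfamily 1 group I member 3 (Homo sapiens), read by a luciferase reporter, with a stated time of 23 h; on this read-out lower numbers stand for an effect already at smaller amounts and higher numbers for an effect only at larger amounts of compound. Compound 1, `C(=N/OCc1ccccc1)\c1c(-c2ccc3ccccc3c2)nc2occn12`, gives 840 nM in this assay. Compound 2, `Clc1ccc(-c2nc3occn3c2/C=N/OCc2ccc(Cl)c(Cl)c2)cc1`, gives 410 nM in this assay, and compound 3, `Clc1ccc(CO/N=C/c2c(-c3ccc(Br)cc3)nc3sccn23)cc1Cl`, gives 480 nM in this assay. Of the three numbers, compound 1 gives the highest; its separation from compound 3 is within the usual scatter of repeated measurements, whereas the separation from compound 2 lies beyond it. No two of these compounds differ in a single place, so no step between measured compounds can be read off.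

Compound 4, `C(=N/OC1Cc2ccccc2C1)\c1c(-c2ccc3ccccc3c2)nc2occn12`, is not yet measured. It differs from compound 1 in one place: 2,3-dihydro-1H-inden-2-yl in place of benzyl on an oxygen. The difference sits on the oxygen whose other neighbour is the double-bonded nitrogen, and cut one bond further out it reads benzyloxy to (2,3-dihydro-1H-inden-2-yl)oxy. For the measured compounds named here, nothing among the measured compounds shows the effect of such a change.

The step from compound 1 to compound 4 in this assay is therefore expected to be small, most likely within the scatter, with no preferred direction, written as a 1.3-fold lower number from compound 1 to compound 4 (0.11 log units; within the scatter). Compound 4 is estimated at 650 nM in this assay, expected to fall between 250 nM and 1700 nM.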

Compound 4, half-maximal effective concentration: 980 nM
Beside the measured number, compound 4's estimate is 1.5-fold (0.18 log units) below it; the range from low to high includes it.
By their numbers in this assay, from the lowest: compounds 2, 3, 1 and 4 (each within the scatter of the next, the first and the last beyond it).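

For the compounds shown here, on the oxygen whose other neighbour is the double-bonded nitrogen, 2,3-dihydro-1H-inden-2-yl in place of benzyl gives a 1.2-fold higher number from compound 1 to compound 4 (0.07 log units; within the scatter) in this assay, the only step that can be read so far. Going by these compounds alone, on the core of compound 1, this position therefore accepts a five-membered non-aromatic ring of carbon on the group without a shift beyond the scatter, which the earlier compounds could not show, as no two of them differed in one place. No measurement at hand offers an explanation for this result.

This single pair does not show whether the same exchange would give a similar step on the core of compound 2 or of compound 3, which carry other groups elsewhere as well as on this oxygen. It also leaves open how the position responds to a group of a different kind, such as a 2-phenylethyl chain, a primary amine at the end of a longer chain or a carboxylic acid in place of benzyl.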